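A few compounds are considered here, and "the series" means these few. Any claim that something is new, unique, unknown or untested is made for them only; others in the source may bear on it.

Compound 1 `Cc1ccc(S(=O)(=O)/C(=C/c2sccc2C)C(=O)c2ccc(Br)cc2)cc1` is the point of departure here. In a functional assay on DU-145 cells (Homo sapiens) for inhibition, read by trypan blue exclusion, with a stated time of 96 h (on this read-out lower numbers stand for stronger inhibition of growth and higher numbers for weaker inhibition of growth), compound 1 gives 25000 nM. Among the two numbers available this is the highest; the nearest is compound 3 `Cc1ccc(S/C(=C/c2c[nH]c3ccccc23)C(=O)c2ccc(Br)cc2)cc1`, which in this assay gives 10000 nM, and the gap between the two lies beyond the usual scatter of such measurements. Compound 2 `Cc1ccc(CS/C(=C/c2ccc(N(C)C)cc2)C(=O)c2ccc(Cl)cc2)cc1` is recorded only as a limit of the assay, since in this assay compound 2 shows > 100000 nM. The record for this series thus contains (the limit of > 100000 nM in this assay, at which 1 of the 3 values shown sits).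

Compound 4 `CSc1ccc(/C=C(\C(=O)c2ccc(Br)cc2)S(=O)(=O)c2ccc(C)cc2)cc1` has not yet been measured. It differs from compound 1 in one place: 4-(methylsulfanyl)phenyl in place of 3-methylthiophen-2-yl on a double-bonded chain carbon bound to a double-bonded chain carbon. Among the compounds with values here, no pair of measured compounds separates this change on its own, so its effect can only be anticipated from what the series shows. Given that compound 1 already sits at 25000 nM and the replacement is a like-for-like exchange of one aromatic group for another, the step expected is a 1.3-fold lower number from compound 1 to compound 4 (0.10 log units; within the scatter), which would fall within the usual scatter rather than beyond it. For compound 4 the estimated value in this assay is 20000 nM, with a range from 6000 nM to 70000 nM.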

Compound 4, concentration for 50% growth inhibition: 1000 nM
Beside the measured number, compound 4's estimate is 20-fold (1.30 log units) above it, and the stated range ends above it.
By their numbers in this assay, from the lowest: compound 4; then compound 3; then compound 1. At a limit, above all of these: compound 2.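

In this assay, the place on a double-bonded chain carbon bound to a double-bonded chain carbon turns out to respond strongly to the choice of aromatic group: 4-(methylsulfanyl)phenyl in place of 3-methylthiophen-2-yl gives a 25-fold lower number from compound 1 to compound 4 (1.40 log units; beyond the scatter). Within the data shown here, the earlier compounds could not show this, as no two of them differed in one place, so this is the first change that can be read on its own. The exchange is therefore far from neutral here, even though the counts of hydrogen-bond donors and acceptors are the same for the group that leaves and the group that enters, and nothing among the measurements shown accounts for the size of the step.

Going by these compounds, the step changes the ring and adds the methylsulfanyl group together, so it remains open which of the two carries the difference; a plain phenyl or a 5-(methylsulfanyl)thiophen-2-yl at this place would separate them. On these data alone, it also remains open how far the methylsulfanyl group can be varied on the ring, for instance by a methoxy group, an amine or a carboxylic acid in its place.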